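The compounds below may be only part of what the source reports. "The series", "measured", "known", "first", "only" and "open" are said of these compounds alone.

Compound 1 `C=C[C@@](C)(/C=C/c1ccc(Nc2ccc(OC(F)(F)F)cc2)cc1)CCC=C(C)C`: in a functional assay on SEM cells (Homo sapiens) for cytotoxicity, with a stated time of 72 h (a lower number here means that less compound is needed, a higher number that more compound is needed for the effect), compound 1 gives > 36600 nM, which is a limit of the assay and not a number.
Compound 2 `C=C[C@@](C)(/C=C/c1ccc(Nc2ccc(F)cc2)cc1)CCC=C(C)C`: in this assay compound 2 gives > 36600 nM, again a limit of the assay rather than a number.

Among the compounds with values here, compound 2 therefore stands at a limit in this assay, and the one other value shown is a limit as well, so that the two compounds sit together at the limit of > 36600 nM in this assay, at which 2 of the 2 values shown sit. Within the data shown here, the single measured step, a step that the two limits leave unreadable from compound 1 to compound 2, is the only one that bears on the new change; its size could not be read, because both ends are limits. Compound 3 `C=C[C@@](C)(/C=C/c1ccc(-c2ccccc2)cc1)CCC=C(C)C` differs from compound 2 in one place: phenyl in place of (4-fluorophenyl)amino on an aromatic carbon. Among the measured compounds shown here, nothing measured so far shows whether this change moves the read-out in either direction, and the one comparable step gave no readable size. The writer expects the step that the limit leaves unreadable from compound 2 to compound 3 in this assay, most likely ending again at the limit of the assay. His estimate for compound 3 in this assay is 45000 nM, with a range from 15000 nM to 150000 nM.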

Compound 3, half-maximal effective concentration: > 36600 nM
Compound 3 ended at the assay's limit (the forecaster's own chance of this, stated with the estimate: 70%); the middle value does not contradict the limit.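

In this assay compound 3 gives > 36600 nM which is again a limit of the assay and not a number. The step between compound 2 and compound 3 therefore cannot be read, as both ends are limits. The compounds shown leave open whether any change to the shared core would bring a measurable value in this assay at all.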